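A new end group on compound 1

The compounds below may be only part of what the source reports. "The series", "measured", "known", "first", "only" and "open" are said of these compounds alone.

compound 1 `C/C(=N\O)C(=O)NCCCCCC(=O)Nc1ccccc1`: > 100000 nM (a limit, not a number)
compound 2 `COc1ccc(NC(=O)CCCCCCNC(=O)C(O)(O)C(F)(F)F)cc1`: 4520 nM
compound 3 `CCOc1ccc(-c2cnc(NC(=O)CCCCCCNC(=O)C(O)(O)C(F)(F)F)s2)cc1`: 4050 nM

All three compounds were tested in a functional assay on HCT-116 cells (Homo sapiens) for inhibition, read by colorimetric assay, with a stated time of 3 days; on this read-out lower numbers stand for stronger inhibition and higher numbers for weaker inhibition. Compound 1 stands at the limit of > 100000 nM in this assay, at which 1 of the 3 values shown sits. That reading is a limit, so it gives no number for compound 1 and marks only where the scale ends. Compound 2 reads 4520 nM and compound 3 reads 4050 nM, so both gave real numbers, close to each other.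

Compound 4 `O=C(CCCCCNC(=O)c1cc(=O)c(O)co1)Nc1ccccc1` has not yet been measured. It differs from compound 1 in one place, on a carbonyl carbon, and the rest of the structure stays the same: a group of 8 heavy atoms (5 carbon, 3 oxygen; one six-membered aromatic ring with 1 hetero atom) in place of a group of 4 heavy atoms (2 carbon, 1 nitrogen, 1 oxygen; no ring), on a carbonyl carbon. Among the measured compounds shown here, no pair of measured compounds differs in one place, so no measured step gauges this change directly. In this assay a modest step towards stronger inhibition is expected, though a result no different from compound 1 would not surprise. The reading of compound 2 at 4520 nM offers only a loose guide to how far such a step might reach. The step expected is an at least 3.3-fold lower number from compound 1 to compound 4 (0.52 log units; beyond the scatter). For compound 4 the estimated value is 30000 nM, with an expected range from 8000 nM to 100000 nM.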

Compound 4, half-maximal inhibitory concentration: > 100000 nM
Compound 4 was reported as a limit; the forecaster's own chance of this, stated with the estimate: 30%; middle value at least 3.3-fold (0.52 log units) away from the limit.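

Compound 1 and compound 4 are both reported as limits and not as numbers, so no step between them can be read: the limit of > 100000 nM in this assay, at which 2 of the 4 values shown sit.

The compounds shown leave open whether the new end group on the carbonyl carbon changes inhibition at all, and how far compound 1 and compound 4 each lie past the end of the scale.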